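Dichloro Substitution on the Benzyloxy Group: Expected Outcome

The compounds below may be only part of what the source reports. "The series", "measured", "known", "first", "only" and "open" are said of these compounds alone.

Measured compounds:
Compound 1 `Cc1ccc(-c2nn(-c3ccccc3)cc2C(=O)NOCc2ccccc2)cc1`: 1870 nM
Compound 2 `O=C(NOCc1ccccc1)c1cn(-c2ccccc2)nc1-c1ccc(Cl)cc1`: 10800 nM

Of the compounds shown here, two have been measured in a functional assay on MCF7 cells (Homo sapiens) for antiproliferative activity, read by MTT assay, with a stated time of 48 h, in the presence of a further agent that is not named here; a higher number here means a weaker inhibitor of growth, a lower number a stronger inhibitor of growth. Compound 1 gives 1870 nM, and compound 2 gives 10800 nM. For the measured compounds named here, compound 2 therefore stands at the higher of the two numbers, and its only neighbour is compound 1, reached by the single change a 5.8-fold higher number from compound 1 to compound 2 (0.76 log units; beyond the scatter).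

Compound 3 `O=C(NOCc1ccc(Cl)cc1Cl)c1cn(-c2ccccc2)nc1-c1ccc(Cl)cc1` is not yet measured. It differs from compound 2 by 2,4-dichlorophenyl in place of phenyl on a saturated chain carbon bound to an oxygen. Going by the values given here, no measured step touches this part of the molecule: the one step available, from compound 1 to compound 2, concerns a substituent on the other aromatic ring, and its size gives no direct guide to what two chlorine atoms on the benzyloxy phenyl will do. With nothing in the data bearing on the change, the step from compound 2 to compound 3 is expected to be a 1.1-fold lower number from compound 2 to compound 3 (0.03 log units; within the scatter), that is, no movement beyond the scatter in either direction. On that basis compound 3 is estimated to give 10000 nM in this assay, with a range from 3000 nM to 35000 nM.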

Compound 3, concentration for 50% growth inhibition: 16200 nM
Compound 3: middle estimate off by 1.6-fold (0.21 log units), on the low side; measured number inside the range.
By their numbers in this assay, from the lowest: compound 1; then compounds 2 and 3 (each within the scatter of the next).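

For the compounds shown here, on the benzyloxy side of the molecule, which no earlier step had touched, 2,4-dichlorophenyl in place of phenyl on a saturated chain carbon bound to an oxygen gives, in this assay, a 1.5-fold higher number from compound 2 to compound 3 (0.18 log units; within the scatter). Going by these compounds alone, this position therefore takes the two chlorine atoms, with eight heavy atoms entering where six leave, without a shift that can be told from the scatter, whereas the one earlier step, chloro in place of methyl on an aromatic carbon, gave a 5.8-fold higher number from compound 1 to compound 2 (0.76 log units; beyond the scatter). Nothing in the data available speaks to the reason for this result.

From the compounds shown here alone, compounds 2 and 3 both carry the chloro group, so it remains open whether the same 2,4-dichlorobenzyl change would also stay within the scatter on the methyl-bearing compound 1, which gives 1870 nM. The pair also leaves open whether a single chlorine on the benzyl phenyl, an amine or a carboxylic acid on that ring, or a longer chain in place of benzyl would move the number beyond the scatter.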